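Swapping the aryl on the carbonyl of compound 1

The compounds below may be only part of what the source reports. "The series", "measured", "known", "first", "only" and "open" are said of these compounds alone.

Compound 1 `COc1cc(-c2nn(-c3cccc(NC(=O)c4ccc(Cl)c(C(F)(F)F)c4)c3)cc2-c2ccncc2)ccc1Cl` was tested in a functional assay on BT-549 cells (Homo sapiens) for inhibition, read by sulforhodamine B assay, with a stated time of 48 h; on this read-out higher numbers stand for weaker inhibition of growth and lower numbers for stronger inhibition of growth. In this assay compound 1 gave only a limit, > 32500 nM, which places it at the weak end of the measured results and corresponds to the limit of > 32500 nM in this assay, at which 1 of the 3 values shown sits. Compound 4 `COc1cc(-c2nn(-c3cccc(NC(=O)Nc4ccc(Cl)c(Cl)c4)c3)cc2-c2ccncc2)ccc1Cl` differs from compound 1 in one place: (3,4-dichlorophenyl)amino in place of 4-chloro-3-(trifluoromethyl)phenyl on a carbonyl carbon. Among the measured compounds shown here, the nearest measured comparison comes from compound 2 `O=C(Nc1cccc(-n2cc(-c3ccncc3)c(-c3ccc(Cl)c(O)c3)n2)c1)Nc1cc(C(F)(F)F)cc(C(F)(F)F)c1` and compound 3 `O=C(Nc1cccc(-n2cc(-c3ccncc3)c(-c3ccc(Cl)c(O)c3)n2)c1)Nc1cccc(C(F)(F)F)c1`, which carry on the carbonyl a group of the same kind as the one entering in compound 4, though on a differently substituted core. In this assay compound 2 gives 2120 nM, and compound 3 gives 21400 nM; the step of a 10-fold higher number from compound 2 to compound 3 (1.00 log units; beyond the scatter) shows that a single trifluoromethyl on that aryl is worth a modest amount. For the measured compounds named here, no measured pair shows the effect of exchanging the directly attached aryl for the amino-linked one, nor the effect of the difference between the cores. Because compound 1 stands only at a limit, the step to compound 4 can only be expected to run toward stronger inhibition, estimated as an at least 2.1-fold lower number from compound 1 to compound 4 (0.33 log units; beyond the scatter), with a real chance that the assay again returns a limit. Compound 4 is therefore estimated at 15000 nM, within 3000 nM to 60000 nM.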

Compound 4, concentration for total growth inhibition: 27600 nM
Estimate against measurement, compound 4: 1.8-fold (0.26 log units) below; the measured number falls inside the stated range.
By their numbers in this assay, from the lowest: compound 2; then compounds 3 and 4 (each within the scatter of the next). At a limit, above all of these: compound 1.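

In this assay compound 1 stands at a limit of the assay, so any step away from it has only a floor: the limit of > 32500 nM in this assay, at which 1 of the 4 values shown sits.

Exchanging 4-chloro-3-(trifluoromethyl)phenyl on the carbonyl carbon for (3,4-dichlorophenyl)amino gives compound 4 a measured number, 27600 nM, the only one shown for the core of compound 1. From the compounds shown here alone, the step reads an at least 1.1-fold lower number from compound 1 to compound 4 (0.07 log units; that floor lies within the scatter); this establishes a readable value at this position with the amino-linked aryl in place, but it does not establish a real gain in inhibition of growth, and the true size of the change remains unknown.

Still open, going by these compounds, is how the amino-linked aryl on this core would respond to a nitrile or a carboxylic acid in place of one chlorine, and whether the trifluoromethyl effect seen on the other core, a 10-fold higher number from compound 2 to compound 3 (1.00 log units; beyond the scatter), carries over to it. Also open, on these data alone, is how much the methoxy of compound 4 and the hydroxyl of compound 3 each contribute, since those two compounds differ in more than one place.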